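Swapping a four-atom side-chain group for aminomethyl

The compounds below may be only part of what the source reports. "The series", "measured", "known", "first", "only" and "open" are said of these compounds alone.

Measured compounds:
- compound 1, `O=C(CN(c1nc(Cl)nc2[nH]cnc12)C1CC1)N[C@@H](CO)C(=O)OCc1ccccc1`, gives 31.9%
- compound 2, `O=C(CN(c1nc(Cl)nc2[nH]cnc12)C1CC1)NCC(=O)OCc1ccccc1`, gives 18.7%
- compound 3, `N=C(N)NCCC[C@H](NC(=O)CN(c1nc(Cl)nc2[nH]cnc12)C1CC1)C(=O)OCc1ccccc1`, gives 23.2%

All three share a core carrying a cyclopropyl amine and an ester of benzyl alcohol; they differ in the side chain on the saturated chain carbon bound to an amide-type nitrogen and a carbonyl carbon. In a functional assay on the whole organism (Tail, strain ICR) with Mus musculus as the target, in the tail flick test, with a stated time of 30 min, at a dose of 25 umol/kg by the oral route (on this read-out lower numbers stand for a weaker effect and higher numbers for a stronger effect at the one dose given), compound 3 stands second of the three numbers, and its gaps to the other two, a number 8.7 percentage points lower from compound 1 to compound 3 (within the scatter) and a number 4.5 percentage points higher from compound 2 to compound 3 (within the scatter), are both within the scatter. Going by the values given here, only the step of a number 13.2 percentage points lower from compound 1 to compound 2 (beyond the scatter) is beyond it.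

Compound 4, `NCCCC[C@H](NC(=O)CN(c1nc(Cl)nc2[nH]cnc12)C1CC1)C(=O)OCc1ccccc1`, differs from compound 3 by a group of 2 heavy atoms (1 carbon, 1 nitrogen; no ring) in place of a group of 4 heavy atoms (1 carbon, 3 nitrogen; no ring), on a saturated chain carbon, four bonds along the chain from an amide-type nitrogen and a carbonyl carbon.

No measured step touches this position four bonds along the chain, so nothing shown speaks directly to it. The nearest comparison is that adding the whole chain in compound 3 gave only a number 4.5 percentage points higher from compound 2 to compound 3 (within the scatter). On that basis the step of a number 0.2 percentage points lower from compound 3 to compound 4 (within the scatter) is expected to stay within the scatter. Compound 4 is estimated at 23%, with a likely range from 10% to 38%.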

Compound 4, a percentage reported as activity, at one dose (the size of the read-out at that dose, not a potency): 26.1%
Compound 4: the middle estimate sits 3.1 percentage points below what was measured; the range from low to high includes it.
By their numbers in this assay, from the lowest: compounds 2, 3, 4 and 1 (each within the scatter of the next, the first and the last beyond it).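

Putting aminomethyl where the group of 4 heavy atoms stood in compound 3, on the saturated chain carbon four bonds along the chain, leaves the result in this assay within the scatter (a number 2.9 percentage points higher from compound 3 to compound 4 (within the scatter)), so at this one dose the read-out does not separate these two chain ends. Compound 4 also cannot be told apart from either of the compounds with a shorter side chain, since 4-aminobutyl in place of hydrogen (a number 7.4 percentage points higher from compound 2 to compound 4 (within the scatter)) and 3-aminopropyl in place of hydroxy (a number 5.8 percentage points lower from compound 1 to compound 4 (within the scatter)) both stay within the scatter, although compound 1 and compound 2 lie beyond it from each other. No supporting measurement explains these small steps.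

On these data alone, whether a carboxylic acid at the chain end would stay within the scatter remains open. So does the effect of a longer chain carrying the same amine.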